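The source may report more compounds than this note shows. Statements on the series, on what has been measured and on what is new or still open speak of the compounds shown alone.

Measured in a functional assay on the whole organism for antagonist activity, with Mus musculus as the target; on this read-out lower numbers stand for an effect already at smaller amounts and higher numbers for an effect only at larger amounts of compound:
- compound 1 `CC(=O)N(C)C(C)C#CCn1ccnc1`: > 100 mg/kg
- compound 2 `CC(=O)N(C)C(C)C#CCn1cncc1C`: 3.7 mg/kg
- compound 3 `Cc1cncn1CC#CCN1C(=O)CCC1C`: 1.4 mg/kg

Compound 1 stands at a limit of the assay, so it gives no number.

For the measured compounds named here, only two true numbers exist in this assay, and compound 2 at 3.7 mg/kg has the higher of them. Compound 3 at 1.4 mg/kg lies lower, with the gap beyond the usual scatter.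

Compound 4 `CC(=O)N(C)CC#CCn1cncc1C` is the next case, and it departs from compound 2 by hydrogen in place of methyl on a saturated chain carbon bound to an amide-type nitrogen and a triple-bonded carbon.

Going by the values given here, no measured step covers this place. Among the compounds with values here, the one measured step, an at least 27-fold lower number from compound 1 to compound 2 (1.43 log units; beyond the scatter), is methyl in place of hydrogen on an aromatic carbon, and it is large and beyond the scatter. It bears only loosely here, showing for this one pair that a single methyl can matter a great deal in this read-out. A loss of methyl is therefore expected to move the number upward, though less sharply and with wide uncertainty.

The expected change is a 2.4-fold higher number from compound 2 to compound 4 (0.39 log units; beyond the scatter), toward a higher number. Compound 4 is estimated at 9 mg/kg, with an expected range of 2.5 mg/kg to 40 mg/kg.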

Compound 4, dose for half-maximal effect: > 100 mg/kg
Compound 4 gave a limit, no number (the forecaster's own chance of this, stated with the estimate: 15%); at least 11-fold (1.04 log units) between middle value and limit.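

Compound 4 stands at a limit in this assay, with > 100 mg/kg, and this is not a number. Hydrogen in place of methyl on a saturated chain carbon bound to an amide-type nitrogen and a triple-bonded carbon gives an at least 27-fold higher number from compound 2 to compound 4 (1.43 log units; beyond the scatter), so this chain position, which no earlier pair covered, is a second place where one methyl separates a measurable compound from a limit, the first being the aromatic carbon in an at least 27-fold lower number from compound 1 to compound 2 (1.43 log units; beyond the scatter). Compound 2 carries both methyl groups, and within these two pairs the loss of either one ends in a limit, so the size of each step is only a minimum and the true gap stays unknown: the limit of > 100 mg/kg in this assay, at which 2 of the 4 values shown sit.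

The compounds shown leave open whether a group larger than methyl at this chain carbon, such as ethyl or a longer chain, would hold, lower or raise the number of compound 2. They also leave open whether a hydroxymethyl group there would be tolerated, and whether hydrogen at the matching carbon would cost as much in the core of compound 3.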